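This account rests on a few compounds, and the source may have more. Where it says the series, first, only, none or still open, it means among the compounds named here.

Working notes on the cyanoguanidine series and the planned step from compound 2 to compound 4.

Three compounds have been run in a functional assay (aorta) with Rattus norvegicus as the target; on this read-out lower numbers stand for stronger inhibition and higher numbers for weaker inhibition. Compound 1, `N#CN/C(=N\C1CCCC1)Nc1cc(Cl)cc(Cl)c1`, gives 75000 nM. Compound 3, `C[C@@H](/N=C(\NC#N)Nc1cc(Cl)cc(Cl)c1)c1ccccc1`, gives 43800 nM. Compound 2, `CC(C)CC/N=C(\NC#N)Nc1cc(C(F)(F)F)cc(C(F)(F)F)c1`, gives 5600 nM, the lowest number of the three; the gaps to compound 3 and to compound 1 both lie beyond the scatter, so compound 2 stands as the strongest inhibitor measured so far. Compound 2 also differs from the other two in more than one place, so the three values alone do not show which part of its structure carries the difference.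

The next compound, compound 4, is `CC(C)/N=C(\NC#N)Nc1cc(C(F)(F)F)cc(C(F)(F)F)c1`. Relative to compound 2 the change is isopropyl in place of isopentyl on a double-bonded nitrogen; the aromatic part is unchanged. Going by the values given here, no pair of measured compounds differing only in this way exists, so the size of this step has no direct precedent in the data. The expectation is a modest loss in this assay, with the step from compound 2 to compound 4 estimated as a 2.1-fold higher number from compound 2 to compound 4 (0.33 log units; beyond the scatter), likely beyond the scatter but not large. Compound 4 is therefore estimated at 12000 nM, within a range from 4000 nM to 40000 nM.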

Compound 4, half-maximal inhibitory concentration: 61000 nM
The estimate for compound 4 lay 5.1-fold (0.71 log units) below the measured number, and the stated range ends below it.
By their numbers in this assay, from the lowest: compound 2; then compounds 3, 4 and 1 (each within the scatter of the next).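

In this assay, going by these compounds alone, compound 2 and compound 4 form the first pair that differs in one place only, and the change of isopentyl to isopropyl on a double-bonded nitrogen gives an 11-fold higher number from compound 2 to compound 4 (1.04 log units; beyond the scatter). This shows that, with the aromatic part held constant, the group at this position can by itself account for a large difference in the read-out, something the earlier compounds could not show because they differed from compound 2 in more than one place. Nothing measured on these compounds bears on why replacing the 5 heavy atoms of isopentyl with the 3 of isopropyl produces a step of this size, so the result stands as an observation without an explanation.

As far as these compounds go, two groups at this position fix only two points, so it remains open whether the number keeps falling with a longer chain such as n-hexyl, or how a chain ending in an amine or a carboxylic acid would compare with isopentyl. Within the data shown here, it also remains open whether a step of this size would recur with the chlorine-bearing aromatic part of compound 1 and compound 3 in place of the one shared by compound 2 and compound 4.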